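Methoxy on the cyclobutyl amide: distribution in rat

The source may report more compounds than this note shows. Statements on the series, on what has been measured and on what is new or still open speak of the compounds shown alone.

Measured compounds:
compound 1 `CCn1c(-c2cnc(C)nc2)nc2c(N[C@H]3CCN(C(=O)[C@H]4C[C@@H](OC)C4)C3)ncnc21` gives 1.5 L/kg
compound 2 `CCn1c(-c2cnc(C)nc2)nc2c(O[C@H]3CCN(C(=O)C4CCC4)C3)ncnc21` gives 0.6 L/kg
compound 3 `CCn1c(-c2cnc(C)nc2)nc2c(N[C@H]3CCN(C(=O)C4CCC4)C3)ncnc21` gives 0.5 L/kg

In an ADME assay (Rattus norvegicus, strain Wistar Han) for pharmacokinetics (on this read-out lower numbers stand for narrower distribution and higher numbers for wider distribution into tissues), compound 3 gives 0.5 L/kg, while compound 1 gives 1.5 L/kg. The change between them is methoxy in place of hydrogen on a saturated ring carbon, and it made a step of a 3.0-fold higher number from compound 3 to compound 1 (0.48 log units; beyond the scatter). Compound 2 gives 0.6 L/kg; the difference between the core of compound 2 and the core of compound 3 is not broken down here. Compound 4 `CCn1c(-c2cnc(C)nc2)nc2c(O[C@H]3CCN(C(=O)[C@H]4C[C@@H](OC)C4)C3)ncnc21` has not yet been measured in this assay. Within the data shown here, it differs from compound 2 by methoxy in place of hydrogen on a saturated ring carbon, the same change as the one from compound 3 to compound 1. Among the measured compounds shown here, the step from compound 2 to compound 4 is expected to be about a 2.5-fold higher number from compound 2 to compound 4 (0.40 log units; beyond the scatter), resting on the single earlier step of a 3.0-fold higher number from compound 3 to compound 1 (0.48 log units; beyond the scatter), with the caveat that it is seen only once and on a different core. Compound 4 is estimated at 1.5 L/kg, between 0.7 L/kg and 3 L/kg.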

Compound 4, volume of distribution: 0.5 L/kg
Compound 4: the middle estimate sits 3.0-fold (0.48 log units) above what was measured, outside the stated range (below it).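

In this assay, methoxy in place of hydrogen on a saturated ring carbon gave a 1.2-fold lower number from compound 2 to compound 4 (0.08 log units; within the scatter) and thus no step beyond the scatter on this core. Set beside the earlier step, the same change did not carry over from one core to the other: the same change on two cores in this assay, a 3.0-fold higher number (0.48 log units; beyond the scatter) from compound 3 to compound 1 and a 1.2-fold lower number (0.08 log units; within the scatter) from compound 2 to compound 4, 3.6-fold (0.56 log units) apart, beyond the scatter of two such steps. This shows that the step seen on one core could not be transferred to the other in this series, but with a single pair on each core it does not show what sets the two apart or how the change would behave on a further core.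

The compounds shown leave open how hydroxy, fluorine or ethoxy in place of methoxy on the cyclobutyl ring would behave on either core. They also leave open whether the other stereoisomer of the 3-methoxycyclobutyl group would give the same steps.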